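The compounds below may be only part of what the source reports. "The series", "measured", "known", "first", "only" and "open" are said of these compounds alone.

Measured compounds:
- compound 1 `O=c1[nH]c(=O)n([C@H]2C[C@H](O)[C@@H](CO)O2)cc1COc1cccc(Br)c1` — 15000 nM
- compound 2 `Cc1ccc(OCc2cn([C@H]3C[C@H](O)[C@@H](CO)O3)c(=O)[nH]c2=O)cc1` — 250000 nM

Both numbers come from a functional assay on HeLa cells (Homo sapiens) for inhibition, with a stated time of 72 h; a higher number here means a weaker inhibitor, a lower number a stronger inhibitor. For the measured compounds named here, compound 1 gives the lowest of the two numbers in this assay; the only other compound, compound 2, sits far above it, the gap being a 17-fold higher number from compound 1 to compound 2 (1.22 log units; beyond the scatter).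

Compound 3 `O=c1[nH]c(=O)n([C@H]2C[C@H](O)[C@@H](CO)O2)cc1COc1ccccc1` is not yet measured. It differs from compound 1 as follows: hydrogen in place of bromo on an aromatic carbon. Going by the values given here, the one measured step, from compound 1 to compound 2, is a different change at the same part of the molecule, 4-methylphenyl in place of 3-bromophenyl, and it is large. It bears on compound 3 only indirectly: it shows that the group on the oxygen on the saturated carbon matters a great deal in this assay, and that the 3-bromophenyl of compound 1 is the better of the two groups seen. Loss of the bromo is therefore expected to move the number upward, by a step smaller than that to compound 2 but likely beyond the scatter; the expected step is a 4.0-fold higher number from compound 1 to compound 3 (0.60 log units; beyond the scatter). Compound 3 is estimated at 60000 nM, within 15000 nM to 250000 nM.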

Compound 3, half-maximal inhibitory concentration: 200000 nM
Compound 3: middle estimate off by 3.3-fold (0.52 log units), on the low side; the measured number falls inside the stated range.
By their numbers in this assay, from the lowest: compound 1; then compounds 3 and 2 (each within the scatter of the next).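

In this assay the single bromine atom on the 3-bromophenyl group carries the whole difference from the plain phenyl: hydrogen in place of bromo gives a 13-fold higher number from compound 1 to compound 3 (1.12 log units; beyond the scatter) and shows that the phenyl group alone does not reproduce the result for compound 1. The methyl of the 4-methylphenyl group, by contrast, cannot be told apart from hydrogen, as hydrogen in its place gives a 1.3-fold lower number from compound 2 to compound 3 (0.10 log units; within the scatter) and places compound 2 and compound 3 together, so the earlier large gap between compound 1 and compound 2 reflects the presence of the bromo on compound 1 and not any contribution from the methyl. Nothing measured here gives a reason for the effect of the bromo.

On these data alone, it remains open whether the effect belongs to bromine itself or would also appear with chloro, iodo, trifluoromethyl or an amine on the same aromatic carbon. A 4-bromophenyl group would show whether the bromo keeps its effect at the position held by the methyl in compound 2, and the present compounds do not settle this.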